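Working notes: aryl ether to aryl thioether on the shared core

This account rests on a few compounds, and the source may have more. Where it says the series, first, only, none or still open, it means among the compounds named here.

Within the data shown here, in a functional assay on SK-OV-3 cells (Homo sapiens) for inhibition, read by sulforhodamine B assay, with a stated time of 48 h (a lower number here means that less compound is tolerated, a higher number that more compound is tolerated), compound 2 `Nc1cc(N)c2nc(-c3ccccc3)c(Oc3ccc(F)cc3)nc2c1` gives 83200 nM, the only number so far. Compound 1 `CCOC(=O)[C@H](CCC(=O)O)NC(=O)c1ccc(Sc2nc3cc(N)cc(N)c3nc2-c2ccccc2)cc1` reaches only a limit in this assay, < 100000 nM, which is not a number; (the limit of < 100000 nM in this assay, at which 1 of the 2 values shown sits). Compound 3 `COc1ccc(Sc2nc3cc(N)cc(N)c3nc2-c2ccccc2)cc1` has not yet been measured. Its change from compound 2 is (4-methoxyphenyl)sulfanyl in place of 4-fluorophenoxy on an aromatic carbon. Among the measured compounds shown here, no measured step between two compounds is at hand, so the size of this step cannot be read from an earlier pair; a step of modest size, at or just beyond the scatter and towards less compound tolerated, is expected, a 1.7-fold lower number from compound 2 to compound 3 (0.22 log units; within the scatter). Compound 3 is expected to give about 50000 nM in this assay, with a range from 15000 nM to 150000 nM.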

Compound 3, concentration lethal to 50% of the cells: < 100000 nM
Compound 3: only a limit was reported; the forecaster's own chance of this, stated with the estimate: 30%; the middle value is on the limit's open side.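

Among these compounds, for compound 3 the result < 100000 nM is a limit and not a number, and no step from compound 2 to compound 3 can be read. On these data alone, how far (4-methoxyphenyl)sulfanyl in place of 4-fluorophenoxy moves the number in this assay stays open.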